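This account rests on a few compounds, and the source may have more. Where it says the series, first, only, none or still open, it means among the compounds named here.

Measured compounds:
- compound 1 `NC(=O)c1c(NC(=O)c2ccccc2F)sc2c1CCN(Cc1cccc(Cl)c1)C2`: 49500 nM
- compound 2 `NC(=O)c1c(NC(=O)c2cccc([N+](=O)[O-])c2)sc2c1CCN(Cc1c(Cl)cccc1Cl)C2`: 46100 nM
- compound 3 `NC(=O)c1c(NC(=O)c2ccccc2Cl)sc2c1CCN(C(=S)Nc1ccccc1Br)C2`: 24600 nM

All three were run in a functional assay on HeLa cells (Homo sapiens) for antiproliferative activity, with a stated time of 24 h; a higher number here means a weaker inhibitor, a lower number a stronger inhibitor. In this assay compound 1 gives 49500 nM, compound 2 gives 46100 nM and compound 3 gives 24600 nM. Compound 3 holds the nominally lowest of the three numbers, but the gap to compound 2 and the gap to compound 1 both lie within the usual scatter, so no ranking among the three can be read from these values. The series as a whole sits in the weak range of this assay.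

Compound 4 `NC(=O)c1c(NC(=O)c2ccccc2Cl)sc2c1CCN(C(=S)Nc1cccnc1)C2` has not been measured. It differs from compound 3 in one place: pyridin-3-yl in place of 2-bromophenyl on an amide-type nitrogen. Among the measured compounds shown here, no measured pair in this set isolates a change of this kind, so the expected step rests on the spread of the three numbers alone. The expected step from compound 3 to compound 4 is none beyond the scatter, a 1.3-fold higher number from compound 3 to compound 4 (0.11 log units; within the scatter), with the estimate leaning a little towards a higher number. Compound 4 is therefore estimated at 32000 nM, in the range 10000 nM to 100000 nM.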

Compound 4, half-maximal inhibitory concentration: > 50000 nM
Compound 4: no number, only a limit; the forecaster's own chance of this, stated with the estimate: 20%; middle value at least 1.5-fold (0.19 log units) away from the limit.
By their numbers in this assay, from the lowest: compounds 3, 2 and 1 (each within the scatter of the next). At a limit, above all of these: compound 4.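

Among the compounds shown here, the swap on the amide-type nitrogen whose other neighbour is the thiocarbonyl carbon is the first one-place change, and in this assay pyridin-3-yl in place of 2-bromophenyl gives an at least 2.0-fold higher number from compound 3 to compound 4 (0.30 log units; that floor lies within the scatter). That floor does not establish a real loss, but the swap brought no gain in this assay, so a ring with one hetero atom and one hydrogen-bond acceptor does not improve on the carbon-only ring here. The reading for compound 4 is a limit and not a number: the limit of > 50000 nM in this assay, at which 1 of the 4 values shown sits.

Whether the bromine or the carbon-only ring accounts for the number of compound 3 stays open, and a plain phenyl would separate the two. Also open, on these data alone, is how a non-aromatic group, such as a short alkyl chain or a morpholine, would read at this nitrogen.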